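Selenocyanate series: shortening the side chain on compound 1

The source may hold more compounds than are shown below. What is called first, only, known or untested is meant among the compounds shown, and "the series" means these compounds.

Measured so far:
compound 1, `COc1ccc(N(C)c2nc(C)nc3ccccc23)cc1C(=O)OCCC[Se]C#N`, 854 nM
compound 2, `C[Se]c1ccc(N(C)c2nc(C)nc3ccccc23)cc1C`, 9 nM
compound 3, `CN(c1ccc([Se]C#N)cc1)c1nc(C2CC2)nc2ccccc12`, 11 nM

In a functional assay on LoVo cells (Homo sapiens) for inhibition, read by MTT assay, with a stated time of 48 h (on this read-out higher numbers stand for weaker inhibition and lower numbers for stronger inhibition), compound 1 gives 854 nM, the highest of the three numbers. Compound 3 gives 11 nM and compound 2 gives 9 nM; both lie far below compound 1, well beyond the scatter, while the values of compound 2 and compound 3 stand within the scatter of each other, so no order is set between those two.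

The next compound, compound 4, `COc1ccc(N(C)c2nc(C)nc3ccccc23)cc1C[Se]C#N`, differs from compound 1 in one place: a group of 4 heavy atoms (2 carbon, 1 nitrogen, 1 selenium; no ring) in place of a group of 9 heavy atoms (5 carbon, 1 nitrogen, 2 oxygen, 1 selenium; no ring), on an aromatic carbon. The group entering keeps the selenocyanate but drops the ester and the three-carbon linker.

Among the compounds with values here, no measured step of this kind is on hand. Still, the two compounds that carry a short selenium-bearing group on the aromatic ring, compound 2 and compound 3, sit far below compound 1, so a sizeable downward step in this assay is expected, beyond the scatter, though the shared core and substitution pattern of compound 4 match only compound 1.

The expected step is a 7.1-fold lower number from compound 1 to compound 4 (0.85 log units; beyond the scatter). For compound 4 the estimate in this assay is 120 nM, with a range from 25 nM to 600 nM.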

Compound 4, half-maximal inhibitory concentration: 277 nM
For compound 4 the middle estimate is 2.3-fold (0.36 log units) below the measured one; low and high end bracket the measured number.
By their numbers in this assay, from the lowest: compounds 2 and 3 (each within the scatter of the next); then compound 4; then compound 1.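

In this assay, replacing the group that holds the ester and three-carbon linker with the shorter selenocyanate-bearing group gives a 3.1-fold lower number from compound 1 to compound 4 (0.49 log units; beyond the scatter) on this aromatic carbon, ortho to a methoxy group and meta to a large group. Within the data shown here, this is the first single-place step, and it is modest but beyond the scatter. The ester and linker are therefore not required for activity at this position, and removing them together leaves open which of the two accounts for the step, with no measurement on hand bearing on its cause.

Going by these compounds, what a thiocyanate, a plain nitrile or an amine would do at this position remains open, as does a longer chain without the ester. Among these compounds, no single-place step connects compound 4 to compound 2 or compound 3, so those comparisons cannot be read.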